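Methyl for Methoxy on the Ester Ring of Compound 1

The source may hold more compounds than are shown below. What is called first, only, known or untested is meant among the compounds shown, and "the series" means these compounds.

Compound 1 `COc1ccc(C(=O)Oc2cc3c(cc2C)[C@@H](C(C)C)CC=C3C)cc1`: 18.6%
Compound 2 `COc1ccc(C(=O)Oc2cc3c(C)ccc(C(C)C)c3cc2C)cc1`: 32.8%
Compound 3 `CC1=CC[C@H](C(C)C)c2cc(C)c(OC(=O)c3ccccc3)cc21`: 37%

In a functional assay on SK-LU-1 cells (Homo sapiens) for antiproliferative activity, read by sulforhodamine B assay, with a stated time of 48 h, tested at 50 uM (a higher number here means more inhibition at the concentration tested (going by the name of the read-out), a lower number less inhibition), compound 1 stands lowest of the three; the number for compound 2 lies beyond the scatter above it, and compound 3 lies further still. Compound 4 `CC1=CC[C@H](C(C)C)c2cc(C)c(OC(=O)c3ccc(C)cc3)cc21` differs from compound 1 by methyl in place of methoxy on an aromatic carbon. Among the measured compounds shown here, only one measured step bears on this: a number 18.4 percentage points higher from compound 1 to compound 3 (beyond the scatter), where the methoxy was taken away altogether and replaced by hydrogen. Putting a methyl in its place is a change in the same direction, though the group is not removed outright, so a rise is expected, likely of similar or somewhat smaller size. The estimated step is a number 12.4 percentage points higher from compound 1 to compound 4 (beyond the scatter). Compound 4 is therefore expected to give 31%, within a range from 17% to 45%.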

Compound 4, a percentage reported as inhibition, at one concentration (the size of the read-out at that concentration, not a potency): 85.4%
Beside the measured number, compound 4's estimate is 54.4 percentage points below it, and the stated range ends below it.
By their numbers in this assay, from the lowest: compound 1; then compounds 2 and 3 (each within the scatter of the next); then compound 4.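

In this assay, swapping methoxy for methyl gives a number 66.8 percentage points higher from compound 1 to compound 4 (beyond the scatter), and adding methyl where compound 3 has only hydrogen gives a number 48.4 percentage points higher from compound 3 to compound 4 (beyond the scatter). Among the compounds shown here, the earlier compounds could suggest only that the number in this assay is higher without methoxy at this position, whereas these steps show that with a small group here the number can be higher than with an empty position, so the choice of group matters, not merely the loss of methoxy. Nothing available explains this gain.

From the compounds shown here alone, whether ethyl, a longer chain, chlorine or an amine at this position would match methyl remains open. So does whether methyl would bring a similar gain on the core of compound 2.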